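From compound 3 to compound 4: a longer chain

The compounds below may be only part of what the source reports. "The series", "measured", "known", "first", "only" and "open" are said of these compounds alone.

Measured in a functional assay on A549 cells (Homo sapiens) for antiproliferative activity, read by MTT assay, with a stated time of 48 h; on this read-out higher numbers stand for weaker inhibition and lower numbers for stronger inhibition:
Compound 1 `Cn1c(N)c(-c2nc3ccccc3[nH]2)c2nc(C#N)c(C#N)nc21`: > 50000 nM, a limit
Compound 2 `N#Cc1nc2c(-c3nc4ccccc4[nH]3)c(N)n(CCN3CCCC3)c2nc1C#N`: > 50000 nM, a limit
Compound 3 `CCN(CC)CCCn1c(N)c(-c2nc3ccccc3[nH]2)c2nc(C#N)c(C#N)nc21`: 25300 nM

Among these results, compound 3 alone gives an actual number, 25300 nM. The remaining evidence is the limit of > 50000 nM in this assay, at which 2 of the 3 values shown sit, so compound 3 cannot be placed exactly against the others.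

The change leading to compound 4 `CCN(CC)CCCCn1c(N)c(-c2nc3ccccc3[nH]2)c2nc(C#N)c(C#N)nc21` is (diethylamino)methyl in place of diethylamino on a saturated chain carbon, three bonds along the chain from an aromatic nitrogen. The same difference can be read as 3-(diethylamino)propyl to 4-(diethylamino)butyl.

Going by the values given here, two measured steps bear on it, though only loosely. One is an at least 1.9-fold lower number from compound 1 to compound 3 (0.29 log units; that floor lies within the scatter), and the other is an at least 1.9-fold lower number from compound 2 to compound 3 (0.29 log units; that floor lies within the scatter). Both rest on limits, so each gives only a floor and not a true size. The third, a step that the two limits leave unreadable from compound 1 to compound 2, offers no usable size. None of them measures the change made here, so they give no firm reason to expect a shift in either direction.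

No step beyond the scatter is therefore expected in this assay, and the expected step is a 1.2-fold lower number from compound 3 to compound 4 (0.06 log units; within the scatter). For compound 4 the estimate is 22000 nM, with an expected range from 8000 nM to 50000 nM.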

Compound 4, half-maximal inhibitory concentration: 5750 nM
The estimate for compound 4 lay 3.8-fold (0.58 log units) above the measured number; measured number outside the range, below it.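

In this assay, the step from 3-(diethylamino)propyl to 4-(diethylamino)butyl gives the first size at this position that is more than a floor: a 4.4-fold lower number from compound 3 to compound 4 (0.64 log units; beyond the scatter). The earlier readable steps offered only floors within the scatter, whereas this result shows that one further chain unit, with the diethylamino group kept in place, is enough to move the number beyond the scatter. The steps to the other two compounds, an at least 8.6-fold lower number from compound 2 to compound 4 (0.93 log units; beyond the scatter) and an at least 8.6-fold lower number from compound 1 to compound 4 (0.93 log units; beyond the scatter), also lie beyond the scatter, so compound 4 is the most potent of the four, although both sizes are only floors: the limit of > 50000 nM in this assay, at which 2 of the 4 values shown sit.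

The compounds shown leave open whether a longer chain, such as 5-(diethylamino)pentyl, would lower the number further or whether the trend stops at the butyl chain. They also do not separate chain length from the amine, since pyrrolidin-1-yl appears only on the shorter chain of compound 2, and neither it nor a ring amine such as morpholine is seen on the butyl chain.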